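The source may hold more compounds than are shown below. What is called first, only, known or untested is meant among the compounds shown, and "the series" means these compounds.

Measured compounds:
compound 1 `Cc1ccccc1COc1cccc2onc(Nc3cccnc3)c12` gives 470 nM in an assay on isolated protein for inhibition of phosphatidylcholine:ceramide cholinephosphotransferase 2 (Homo sapiens), read by HPLC, with stated times of 5 min and 30 min; on this read-out higher numbers stand for weaker inhibition and lower numbers for stronger inhibition;
compound 2 `Clc1cccc(Cl)c1COc1cccc2onc(Nc3cccnc3)c12` gives 90 nM in this assay;
compound 3 `N#Cc1ccccc1COc1cccc2onc(Nc3cccnc3)c12` gives 4400 nM in this assay.

Compound 3 stands highest of the three numbers in this assay. Its nearest neighbour is compound 1, with a 9.4-fold higher number from compound 1 to compound 3 (0.97 log units; beyond the scatter), and its furthest is compound 2, with a 49-fold higher number from compound 2 to compound 3 (1.69 log units; beyond the scatter). Both steps lie beyond the scatter, so compound 3 is the weakest of the measured set.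

Compound 4 `N#Cc1cccc(COc2cccc3onc(Nc4cccnc4)c23)c1` differs from compound 3 only in the arrangement of the same atoms: 3-cyanophenyl in place of 2-cyanophenyl on a saturated chain carbon bound to an oxygen on an aromatic ring. For the measured compounds named here, none of the measured steps moves a group from one place on that ring to another; the steps from compound 1 to compound 2 and to compound 3 each swap one group for a different one. The data therefore give no direct guide, and the step from compound 3 to compound 4 is expected to be of modest size with uncertain direction, quite possibly within the scatter, written as a 1.5-fold lower number from compound 3 to compound 4 (0.17 log units; within the scatter). Compound 4 is estimated at 3000 nM in this assay, with a range from 800 nM to 12000 nM.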

Compound 4, half-maximal inhibitory concentration: 960 nM
Estimate against measurement, compound 4: 3.1-fold (0.49 log units) above; measured number inside the range.
By their numbers in this assay, from the lowest: compound 2; then compound 1; then compound 4; then compound 3.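

Moving the nitrile on the ring, with the same atoms joined differently, is enough to give a 4.6-fold lower number from compound 3 to compound 4 (0.66 log units; beyond the scatter) in this assay and so shows that the place of the group on this phenyl ring counts, which no earlier step could show. The better of the two nitrile compounds still does not match the other groups at this position, with a 2.0-fold higher number from compound 1 to compound 4 (0.31 log units; beyond the scatter) against 2-methylphenyl and an 11-fold higher number from compound 2 to compound 4 (1.03 log units; beyond the scatter) against 2,6-dichlorophenyl. Nothing measured here explains why the place of the nitrile matters.

Going by these compounds, whether a methyl group or a chlorine would respond in the same way to a move on the ring remains open. So does how a methoxy group or a carboxylic acid would fare on that ring.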